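Methyl for cyano on the sulfonyl aryl of a quinoline series

The compounds below may be only part of what the source reports. "The series", "measured", "known", "first", "only" and "open" are said of these compounds alone.

Of the compounds shown here, three sharing one core have been measured in an assay on isolated protein for displacement of a labelled ligand from metabotropic glutamate receptor 5 (Homo sapiens), with a stated time of 60 min, tested at 1 uM; a lower number here means less inhibition, a higher number more inhibition at the concentration tested (going by the name of the read-out). Among the measured compounds shown here, compound 1 `Cc1ccc(S(=O)(=O)c2cnc3ccc(F)cc3c2N2CCC(C)CC2)cc1` gives 91%, and compound 2 `Cc1ccc(S(=O)(=O)c2cnc3ccc(Cl)cc3c2N2CCC(C)CC2)cc1` gives 95%; the step of a number 4 percentage points higher from compound 1 to compound 2 (within the scatter) is the only one-change step among them. Compound 3 `Cc1ccc2ncc(S(=O)(=O)c3ccc(C#N)cc3)c(N3CCC(C)CC3)c2c1`, whose sulfonyl aryl carries a cyano group, gives 55%, the lowest of the three numbers, well beyond the scatter below both compound 1 and compound 2.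

Compound 4 `Cc1ccc(S(=O)(=O)c2cnc3ccc(C)cc3c2N2CCC(C)CC2)cc1` is not yet measured. It differs from compound 3 in one place: methyl in place of cyano on an aromatic carbon. For the measured compounds named here, the single measured step, from fluoro to chloro on the core, does not touch the sulfonyl aryl and so says little about this change. What does bear on it is that compound 1 and compound 2 both carry the same 4-methylphenyl sulfone that compound 4 acquires, and both sit far above compound 3. A step upward, beyond the scatter, is therefore expected in this assay. The step of a number 30 percentage points higher from compound 3 to compound 4 (beyond the scatter) is the size expected here. For compound 4 the estimated value is 85%, with a likely range from 65% to 98%.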

Compound 4, a percentage reported as inhibition, at one concentration (the size of the read-out at that concentration, not a potency): 82%
The estimate for compound 4 lay 3 percentage points above the measured number, and the stated range covers the measured number.
By their numbers in this assay, from the lowest: compound 3; then compounds 4, 1 and 2 (each within the scatter of the next, the first and the last beyond it).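

The gap between compound 3 and the two halogen compounds could not be assigned to one place before, since they differ in two; with the methyl on the core held fixed, a number 27 percentage points higher from compound 3 to compound 4 (beyond the scatter) in this assay ties a step beyond the scatter to the change from 4-cyanophenyl to 4-methylphenyl alone. Compound 4 also links the core position to the earlier pair: a number 13 percentage points lower from compound 2 to compound 4 (beyond the scatter) is a step beyond the scatter, whereas a number 9 percentage points lower from compound 1 to compound 4 (within the scatter) stays within it, so at this position only methyl and chloro are told apart, and fluoro separates from neither. Nothing available on these compounds gives a reason for either step.

Going by these compounds, whether the cyano step keeps its size with fluoro or chloro on the core remains open, as does how a methoxy group, a trifluoromethyl group, a carboxylic acid or an amine would read in place of the methyl on the sulfonyl aryl. On these data alone, all of these numbers come from one tested concentration, so how the compounds rank in potency also stays open.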